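This account rests on a few compounds, and the source may have more. Where it says the series, first, only, none or still open, it means among the compounds named here.

In a functional assay on MT4 cells (Homo sapiens) for cytotoxicity (on this read-out higher numbers stand for lower toxicity in this test and lower numbers for higher toxicity in this test), compound 1 `Cc1c(O)nc(SCC(=O)c2ccc(Cl)cc2)nc1Cc1cccc2ccccc12` gives >= 198000 nM, which is a limit and not a number. Compound 2 `COC(=O)CSc1nc(O)c(C)c(Cc2cccc3ccccc23)n1` also stands at a limit, >= 296000 nM. So neither compound has a measured value to build on. Compound 3 `CC(C)c1c(O)nc(SCC(=O)c2ccc(Cl)cc2)nc1Cc1cccc2ccccc12` keeps the rest of compound 1 but carries isopropyl in place of methyl on an aromatic carbon, ortho to a hydroxy group: isopropyl in place of methyl on an aromatic carbon. Within the data shown here, the only measured step, a step that the two limits leave unreadable from compound 1 to compound 2, changes another part of the molecule and gives no size, so it offers only weak guidance. A small move towards lower numbers in this assay, not clearly beyond the scatter, is therefore expected, and the result may again be only a limit. The expected change is an at least 1.3-fold lower number from compound 1 to compound 3 (0.12 log units; that floor lies within the scatter). For compound 3 the estimated value is 150000 nM, with an expected range from 50000 nM to 280000 nM.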

Compound 3, half-maximal cytotoxic concentration: > 270000 nM
Compound 3 ended at the assay's limit; the forecaster's own chance of this, stated with the estimate: 55%; middle value at least 1.8-fold (0.25 log units) away from the limit.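

In this assay compound 3 gives > 270000 nM, which is a limit and not a number. Compound 1 also stands at a limit, so the step between compound 1 and compound 3 cannot be read. The compounds shown leave open how far isopropyl in place of methyl shifts the cytotoxic concentration.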